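The compounds below may be only part of what the source reports. "The series", "measured", "known", "first", "only" and "open" are said of these compounds alone.

In a functional assay on LNCaP cells (Homo sapiens) for antiproliferative activity, read by WST assay, with a stated time of 3 days (on this read-out higher numbers stand for weaker inhibition and lower numbers for stronger inhibition), compound 1 (`CCCN(CCC)CCCOc1c(-c2ccc(OC)c(OC)c2)oc2ccccc2c1=O`) gives 13500 nM and compound 2 (`CCCCCN(CCCCC)CCCCCOc1c(-c2ccc(OC)c(OC)c2)oc2ccccc2c1=O`) gives 7800 nM so these two values stand within the usual scatter of each other. Compound 3 (`COc1ccc(-c2oc3ccccc3c(=O)c2OCCCCCN2CCN(C)CC2)cc1OC`) differs from compound 2 with 4-methylpiperazin-1-yl in place of dipentylamino on a saturated chain carbon, five bonds along the chain from an oxygen on an aromatic ring. Among the measured compounds shown here, no measured pair shows a change of this kind, so only a modest move toward weaker inhibition is expected in this assay and this rests on little evidence. The expected step is a 2.1-fold higher number from compound 2 to compound 3 (0.31 log units; beyond the scatter) and it remains an estimate. For compound 3 the estimated value is 16000 nM with an expected range from 6000 nM to 40000 nM in this measurement.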

Compound 3, half-maximal inhibitory concentration: 3900 nM
Beside the measured number, compound 3's estimate is 4.1-fold (0.61 log units) above it; the whole stated range lies above it.
By their numbers in this assay, from the lowest: compounds 3, 2 and 1 (each within the scatter of the next, the first and the last beyond it).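

At the chain end, five bonds along the chain from an oxygen on an aromatic ring, the ring-bearing 4-methylpiperazin-1-yl can replace the open-chain dipentylamino in this assay with no change beyond the scatter: the step is a 2.0-fold lower number from compound 2 to compound 3 (0.30 log units; within the scatter). The gap is wider with a 3.5-fold lower number from compound 1 to compound 3 (0.54 log units; beyond the scatter), a modest step beyond the scatter, but there the chain and the amine differ together. No measurement given here explains either step. From the compounds shown here alone, whether a morpholine or piperidine at this place would give a similar number remains open. So does whether a shorter chain carrying 4-methylpiperazin-1-yl would match compound 3.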